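The compounds below may be only part of what the source reports. "The series", "measured", "known", "first", "only" and "open" are said of these compounds alone.

Compound 1 `CCCS(=O)(=O)Nc1cccc2c1CCC2c1ncc[nH]1` gives 54% in a functional assay on CHO cells for agonist activity at Alpha-1A adrenergic receptor (Homo sapiens), read by FLIPR and calcium flux; on this read-out higher numbers stand for larger maximal responses and lower numbers for smaller maximal responses. For the measured compounds named here, no measured compound exceeds it: compound 3 `c1ccc(-c2cccc3c2CCC3c2ncc[nH]2)nc1`, with 53%, sits within the scatter of it, whereas compound 2 `Clc1ccc2c(c1-c1ccn[nH]1)CCC2c1ncc[nH]1`, with 40%, lies beyond the scatter below it. Going by the values given here, the one single-point step available is a number 1 percentage points lower from compound 1 to compound 3 (within the scatter), a change within the scatter.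

Compound 4 `c1cc(-c2ccn[nH]2)c2c(c1)C(c1ncc[nH]1)CC2` differs from compound 1 in one place: 1H-pyrazol-5-yl in place of (propylsulfonyl)amino on an aromatic carbon. The step to compound 3 bears on this, since it too exchanged the (propylsulfonyl)amino for an aromatic ring and moved the number hardly at all. Among the compounds with values here, compound 2 carries the same 1H-pyrazol-5-yl together with a chlorine and shows a smaller value, but no single-point step links it to compound 1. The expected step is a number 7 percentage points lower from compound 1 to compound 4 (within the scatter), a small drop. Compound 4 is estimated at 47%, within 34% to 60%.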

Compound 4, largest response reached (Emax), in percent of the reference or control that the assay uses: 83%
The estimate for compound 4 lay 36 percentage points below the measured number; measured number above the stated range.
By their numbers in this assay, from the lowest: compound 2; then compounds 3 and 1 (each within the scatter of the next); then compound 4.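

On this aromatic carbon the choice of ring matters: with 1H-pyrazol-5-yl in place of pyridin-2-yl, this assay shows a number 30 percentage points higher from compound 3 to compound 4 (beyond the scatter), and with it in place of (propylsulfonyl)amino, a number 29 percentage points higher from compound 1 to compound 4 (beyond the scatter). Removing the chloro gives the largest change, with hydrogen in its place producing a number 43 percentage points higher from compound 2 to compound 4 (beyond the scatter). No measurement at hand gives a reason for these rises. Still open, as far as these compounds go, is whether another five-membered aromatic ring, such as an imidazole or a thiazole, would match the 1H-pyrazol-5-yl on this carbon. Also open, from the compounds shown here alone, is how a methyl or fluorine in place of the chloro would behave.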